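Chloro to methyl swaps in a naphthyl ether uracil series

The source may hold more compounds than are shown below. What is called first, only, known or untested is meant among the compounds shown, and "the series" means these compounds.

Three members of the series have been measured. Compound 1 `N#Cc1ccc2c(Cl)cc(Oc3ccccc3OCCn3ccc(=O)[nH]c3=O)cc2c1` gives 12000 nM in a toxicity assay on MT2 cells (Homo sapiens) for cytotoxicity, read by MTT assay; on this read-out higher numbers stand for lower toxicity in this test and lower numbers for higher toxicity in this test. Compound 2 `Cc1cc(Oc2ccccc2OCCn2ccc(=O)[nH]c2=O)cc2cc(C#N)ccc12` gives 6000 nM in this assay. Compound 3 `Cc1cc(Oc2ccccc2OCCn2ccc(=O)[nH]c2=O)c(Cl)c2cc(C#N)ccc12` returns only a limit of this assay, > 100000 nM, and no number; this is the limit of > 100000 nM in this assay, at which 1 of the 3 values shown sits.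

Between compound 1 and compound 2 the change is methyl in place of chloro on an aromatic carbon, and it gives a 2.0-fold lower number from compound 1 to compound 2 (0.30 log units; within the scatter). Between compound 2 and compound 3 the change is chloro in place of hydrogen on an aromatic carbon, giving an at least 16-fold higher number from compound 2 to compound 3 (1.22 log units; beyond the scatter); since compound 3 sits at a limit, the true size of that step is open upward.

Compound 4 `Cc1cc(Oc2ccccc2OCCn2ccc(=O)[nH]c2=O)c(C)c2cc(C#N)ccc12` remains to be measured in this assay. It differs from compound 3 by methyl in place of chloro on an aromatic carbon. Among the compounds with values here, this is the same kind of change as the one from compound 1 to compound 2, but not the same: in compound 4 the place is ortho to a large group and para to a methyl group, whereas in compound 2 the place is meta to a large group. How the core of compound 1 differs from the core of compound 3 is not broken down here.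

The expected step from compound 3 to compound 4 is an at least 1.2-fold lower number from compound 3 to compound 4 (0.09 log units; that floor lies within the scatter), set beside a 2.0-fold lower number from compound 1 to compound 2 (0.30 log units; within the scatter), which was within the scatter. Because compound 3 already sits at the limit of > 100000 nM in this assay, at which 1 of the 3 values shown sits, compound 4 is expected to return a limit again rather often. Compound 4 is estimated at 80000 nM in this assay, between 30000 nM and 250000 nM.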

Compound 4, half-maximal cytotoxic concentration: > 100000 nM
Compound 4: no number, only a limit; the forecaster's own chance of this, stated with the estimate: 50%; at least 1.2-fold (0.09 log units) between middle value and limit.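

In this assay compound 4 returns > 100000 nM, which is a limit and not a number, and it is the same limit that compound 3 holds: the limit of > 100000 nM in this assay, at which 2 of the 4 values shown sit.

Since both ends of the step from compound 3 to compound 4 are limits, that step cannot be read, so this core gives no size to set against a 2.0-fold lower number from compound 1 to compound 2 (0.30 log units; within the scatter), and the data neither show nor exclude that methyl in place of chloro carries over from one core to the other. What can be read is an at least 16-fold higher number from compound 2 to compound 4 (1.22 log units; beyond the scatter), which stands with an at least 16-fold higher number from compound 2 to compound 3 (1.22 log units; beyond the scatter): at the place ortho to a large group, methyl and chloro each give a large step from compound 2, so the higher number on this core does not rest on chloro alone, although the true size of both steps is open upward.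

The compounds shown leave open how far compound 3 and compound 4 differ from each other, since neither has a number in this read-out. They also leave open whether a different group at this place, such as an amine or a carboxylic acid, would give a number that can be read rather than a limit.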